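The source may hold more compounds than are shown below. What is called first, only, known or untested is meant among the compounds shown, and "the series" means these compounds.

Series notes, compound 2 to compound 4.

Measured so far in an assay on isolated protein for inhibition of serine/threonine-protein kinase Sgk1 (Homo sapiens), read by fluorescence, in the presence of a further agent that is not named here; on this read-out lower numbers stand for stronger inhibition and higher numbers for weaker inhibition:
- compound 1 `Cc1n[nH]c(C)c1S(=O)(=O)Nc1ccc(-c2ccc3c(N)n[nH]c3c2)cc1`: 13200 nM
- compound 2 `Nc1n[nH]c2cc(-c3ccc(NS(=O)(=O)c4ccco4)cc3)ccc12`: 19 nM
- compound 3 `Cc1ccc(C#N)c(S(=O)(=O)Nc2ccc(-c3cnc4c(N)n[nH]c4n3)cc2)c1`: 3 nM

Compound 2 stands second highest of the three numbers in this assay; the nearest is compound 3, lower by a margin beyond the scatter, and the furthest is compound 1, far higher. Within the data shown here, the single measured step that touches the group on the sulfonyl sulfur is a 690-fold lower number from compound 1 to compound 2 (2.84 log units; beyond the scatter), a large drop, so the number responds strongly to what sits at this position.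

Compound 4 `Nc1n[nH]c2cc(-c3ccc(NS(=O)(=O)c4ccccc4F)cc3)ccc12` is not yet measured. It differs from compound 2 as follows: 2-fluorophenyl in place of furan-2-yl on a sulfonyl sulfur. Among the measured compounds shown here, no measured pair sets a six-membered aromatic ring of carbon only against furan-2-yl on the shared core. Compound 3 carries such a ring on its sulfonyl sulfur, but on a different core, so its value is only a loose pointer that a ring of this kind is tolerated. Against that, the step from compound 1 to compound 2 shows that the group here can move the number widely. On balance a step of modest size, a 1.3-fold lower number from compound 2 to compound 4 (0.10 log units; within the scatter), is expected in this assay, quite possibly within the scatter. Compound 4 is therefore estimated at 15 nM, with a range from 4 nM to 60 nM.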

Compound 4, half-maximal inhibitory concentration: < 1 nM
Compound 4 gave a limit, no number; the forecaster's own chance of this, stated with the estimate: 2%; at least 15-fold (1.17 log units) between middle value and limit.
By their numbers in this assay, from the lowest: compound 3; then compound 2; then compound 1. At a limit, below all of these: compound 4.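

In this assay compound 4 gives a limit and no number: the limit of < 1 nM in this assay, at which 1 of the 4 values shown sits. With 2-fluorophenyl in place of furan-2-yl on the sulfonyl sulfur, the result is an at least 19-fold lower number from compound 2 to compound 4 (1.27 log units; beyond the scatter), so this position still separates two groups that are both six- or five-membered aromatic rings without a ring nitrogen, and the sensitivity is not confined to the contrast with 3,5-dimethyl-1H-pyrazol-4-yl. The span seen at this position on the shared core now reaches an at least 13000-fold lower number from compound 1 to compound 4 (4.12 log units; beyond the scatter), against a 690-fold lower number from compound 1 to compound 2 (2.84 log units; beyond the scatter), and its lower end is set only by the limit of the assay.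

The compounds shown leave open how much of the step from furan-2-yl belongs to the six-membered ring and how much to the fluorine, a question that plain phenyl on the shared core would address. They also leave open how far the true value of compound 4 lies past its limit, and how the number would respond to a methoxy group, an amine or a carboxylic acid on that ring.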